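Chalcone pair: methoxy to hydroxy on reversed cores

A few compounds are considered here, and "the series" means these few. Any claim that something is new, unique, unknown or untested is made for them only; others in the source may bear on it.

Measured so far in a functional assay on HepG2 cells (Homo sapiens) for antiproliferative activity, read by sulforhodamine B assay, with a stated time of 48 h; on this read-out lower numbers stand for stronger inhibition and higher numbers for weaker inhibition:
- compound 1 `COc1ccc(/C=C/C(=O)c2ccccc2-c2ccc(F)cc2)cc1OC`: 95 nM
- compound 2 `COc1cc(/C=C/C(=O)c2ccccc2-c2ccc(F)cc2)ccc1O`: 2800 nM
- compound 3 `COc1ccc(C(=O)/C=C/c2ccccc2-c2ccc(F)cc2)cc1OC`: 6600 nM

Compound 1 gives the lowest number of the three in this assay. Compound 2 differs from it in one place, (hydrogen in place of methyl on an oxygen on an aromatic ring), and the step is a 29-fold higher number from compound 1 to compound 2 (1.47 log units; beyond the scatter). Compound 3 carries the same atoms as compound 1 joined differently; the difference between the two cores is not broken down here. Compound 3 stands highest of the three numbers, and its value and that of compound 2 lie apart by more than the usual scatter.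

Compound 4 `COc1cc(C(=O)/C=C/c2ccccc2-c2ccc(F)cc2)ccc1O` has not yet been measured in this assay. It differs from compound 3 as hydrogen in place of methyl on an oxygen on an aromatic ring. This is the same change, at a place described in the same words, as the one between compound 1 and compound 2, which occurs twice among the compounds shown.

Because the step of a 29-fold higher number from compound 1 to compound 2 (1.47 log units; beyond the scatter) was large, the step from compound 3 to compound 4 is expected to point the same way, while its size is taken with some caution, since it rests on a single measured pair on a core whose difference from that of compound 3 is not broken down here. The expected step is a 7.6-fold higher number from compound 3 to compound 4 (0.88 log units; beyond the scatter). For compound 4 the estimate in this assay is 50000 nM, with a range from 12000 nM to 200000 nM; a measurement reported only as a limit would not be surprising.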

Compound 4, half-maximal inhibitory concentration: 3100 nM
Beside the measured number, compound 4's estimate is 16-fold (1.21 log units) above it, and the stated range ends above it.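

In this assay, the same replacement of methoxy by hydroxy on the second core gives a 2.1-fold lower number from compound 3 to compound 4 (0.33 log units; beyond the scatter), so the change carries over from one core to the other in neither direction nor size: the same change on two cores in this assay, a 29-fold higher number (1.47 log units; beyond the scatter) from compound 1 to compound 2 and a 2.1-fold lower number (0.33 log units; beyond the scatter) from compound 3 to compound 4, 63-fold (1.80 log units) apart, beyond the scatter of two such steps. In this series, the large step seen on the core of compound 1 therefore cannot serve as a general value for this change, and a step measured on one of these two cores gives no reliable estimate for the same change on the other. The result does not show why the two cores differ, and with a single measured pair on each core it does not show how either step would hold up on further pairs or which of the two, if either, is typical of the wider series.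

Still open, on these data alone, is whether an ethoxy group, a longer chain on the same oxygen or an amine in place of that oxygen would follow the step on the core of compound 1, the step on the core of compound 3, or neither. As far as these compounds go, it is also open whether the two cores would still respond differently to this change with a chlorine or a methyl in place of the fluorine.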